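Swapping the acetyl on compound 2 for a chloro

The source may hold more compounds than are shown below. What is called first, only, known or untested is meant among the compounds shown, and "the series" means these compounds.

The three measured compounds share one core and differ only in the group at the end of the biaryl. Compound 1, `CC(C)N(Cc1cccc(OCCCCCC(=O)O)c1)C(=O)c1ccc(-c2cccc3ccccc23)cc1`, carries a naphthalen-1-yl there; in an ADME assay on BJ cells (Homo sapiens) for cytotoxicity, read by CellTiter-Glo and resazurin assay, with a stated time of 72 h (a higher number here means that more compound is needed for the effect, a lower number that less compound is needed), compound 1 gives < 1.3 nM, which is a limit of the assay rather than a number. Compound 2, `CC(=O)c1cccc(-c2ccc(C(=O)N(Cc3cccc(OCCCCCC(=O)O)c3)C(C)C)cc2)c1`, carries a 3-acetylphenyl instead. In this assay compound 2 gives > 26000 nM, again a limit and not a number, so compound 2 stands only at the upper edge of what the assay reports (the limit of > 26000 nM in this assay, at which 1 of the 3 values shown sits). The step of an at least 20000-fold higher number from compound 1 to compound 2 (4.30 log units; beyond the scatter) is therefore large. Compound 3, `CC(C)N(Cc1cccc(OCCCCCC(=O)O)c1)C(=O)c1ccc(-c2cccc(Oc3ccccc3)c2)cc1`, bears a phenoxy in place of the acetyl. Compound 3 gives > 18700 nM, also a limit. The step that the two limits leave unreadable from compound 2 to compound 3 cannot be read, as both ends are limits.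

Compound 4, `CC(C)N(Cc1cccc(OCCCCCC(=O)O)c1)C(=O)c1ccc(-c2cccc(Cl)c2)cc1`, changes compound 2 by chloro in place of acetyl on an aromatic carbon. Both measured steps from compound 2 point the same way: a large fall in the number only when the naphthalen-1-yl is present, and no readable change when the acetyl is replaced by another group. Compound 4 is therefore expected to remain near the limit, with an expected step of an at least 1.3-fold lower number from compound 2 to compound 4 (0.11 log units; that floor lies within the scatter). The estimate for compound 4 is 20000 nM, within 2000 nM to 30000 nM.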

Compound 4, half-maximal effective concentration: > 21900 nM
Compound 4: no number, only a limit; the forecaster's own chance of this, stated with the estimate: 60%; middle value at least 1.0-fold (0.03 log units) away from the limit.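

In this assay compound 4 gives > 21900 nM, which is a limit of the assay and not a number. The steps from compound 2 and compound 3 to compound 4 cannot be read, as both ends of each are limits, so acetyl, phenoxy and chloro cannot be put in any order here. What is new is that chloro, with 1 heavy atom and no hydrogen-bond acceptor, still leaves the compound far from the naphthalen-1-yl compound, with an at least 16000-fold higher number from compound 1 to compound 4 (4.22 log units; beyond the scatter); among the four compounds, the very low limit therefore goes with the naphthalen-1-yl alone, and the high limit does not depend on the carbonyl of the acetyl or on the extra ring of the phenoxy.

On these data alone, since compound 2, compound 3 and compound 4 all sit at limits, their true values, and any differences among them, remain unknown. As far as these compounds go, it also stays open what in the naphthalen-1-yl matters, for instance whether a naphthalen-2-yl or a 3-aminophenyl in the same place would fall close to compound 1 or stay with the three compounds at the high limits.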